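The source may hold more compounds than are shown below. What is called first, only, known or untested is meant among the compounds shown, and "the series" means these compounds.

Measured compounds:
compound 1, `CC(C)C(Cc1ncc[nH]1)c1ccc(-c2ccc3cccc(F)c3c2)[nH]c1=O`, 76 nM
compound 2, `CC(C)C(/C=C1/CCNC1=O)c1ccc(-c2ccc3cccc(F)c3c2)[nH]c1=O`, 8.1 nM

In a functional assay on CHO cells for antagonist activity at prostaglandin E2 receptor EP3 subtype (Homo sapiens), read by cAMP accumulation (on this read-out higher numbers stand for weaker inhibition and lower numbers for stronger inhibition), compound 2 stands lowest of the two numbers; its nearest neighbour is compound 1, at a higher value. Compound 3, `CC(C)NC(=O)CC(c1ccc(-c2ccc3cccc(F)c3c2)[nH]c1=O)C(C)C`, has not yet been measured. It differs from compound 2 by a group of 7 heavy atoms (5 carbon, 1 nitrogen, 1 oxygen; no ring) in place of a group of 7 heavy atoms (5 carbon, 1 nitrogen, 1 oxygen; one five-membered non-aromatic ring with 1 hetero atom), on a saturated chain carbon bound to an aromatic carbon and a saturated chain carbon. Within the data shown here, the only measured step at this place is a 9.4-fold lower number from compound 1 to compound 2 (0.97 log units; beyond the scatter), which shows that the group on this chain carbon moves the number well beyond the scatter. Among the measured compounds shown here, no step ties a ring-opened chain to the lactam, so the direction is uncertain; compound 3 is expected to give a modestly higher number, a 3.7-fold higher number from compound 2 to compound 3 (0.57 log units; beyond the scatter), with an estimate of 30 nM (range 8 nM to 120 nM).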

Compound 3, half-maximal inhibitory concentration: 15 nM
Estimate against measurement, compound 3: 2.0-fold (0.30 log units) above, within the range that was stated.
By their numbers in this assay, from the lowest: compounds 2 and 3 (each within the scatter of the next); then compound 1.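

In this assay, the step of a 1.9-fold higher number from compound 2 to compound 3 (0.27 log units; within the scatter) lies within the scatter, so on this saturated chain carbon the (isopropylcarbamoyl)methyl group, which has no ring, holds the number as well as the ring-bearing group it replaces. Isopropylcarbamoyl in place of 1H-imidazol-2-yl gives a 5.1-fold lower number from compound 1 to compound 3 (0.70 log units; beyond the scatter), so a ring in this group is not needed to pass the imidazole compound. Nothing measured here explains either step. Still open, as far as these compounds go, is whether a shorter chain, a carboxylic acid or an amine in place of the isopropylcarbamoyl would hold the number.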